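The source may hold more compounds than are shown below. What is called first, only, known or untested is meant among the compounds shown, and "the series" means these compounds.

In a functional assay on MDA-MB-231 cells (Homo sapiens) for inhibition, read by MTT assay, with a stated time of 72 h (on this read-out higher numbers stand for weaker inhibition and lower numbers for stronger inhibition), compound 1 `O=C(CSc1nc(Nc2ccccc2)c2ccccc2n1)Nc1cccc(Br)c1` gives 17500 nM, and compound 2 `C=CC(=O)Nc1cccc(NC(=O)CSc2nc(Nc3cccc(F)c3)c3ccccc3n2)c1` gives 8160 nM. Of these two numbers, compound 2 has the lower one, and its distance from compound 1 lies beyond the scatter of repeated measurements, so compound 2 stands as the stronger inhibitor of the pair. The two differ in more than one place, so no single structural cause can be read from them.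

Compound 3 `C=CC(=O)Nc1cccc(NC(=O)CSc2nc(Nc3ccc(Cl)cc3)c3ccccc3n2)c1` differs from compound 2 in one place: 4-chlorophenyl in place of 3-fluorophenyl on a nitrogen on an aromatic ring. Among the compounds with values here, no measured pair shows this particular exchange, so its effect is unknown here. Compound 3 is expected to sit close to compound 2, with a step from compound 2 to compound 3 of a 1.0-fold lower number from compound 2 to compound 3 (0.01 log units; within the scatter) in this assay, no larger than the usual scatter. Compound 3 is therefore estimated at 8000 nM, within a range from 3000 nM to 20000 nM.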

Compound 3, half-maximal inhibitory concentration: 10300 nM
Compound 3: middle estimate off by 1.3-fold (0.11 log units), on the low side; measured number inside the range.
By their numbers in this assay, from the lowest: compounds 2, 3 and 1 (each within the scatter of the next, the first and the last beyond it).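

Within the data shown here, this is the first change in the set that can be read in one place. In this assay, putting 4-chlorophenyl in place of 3-fluorophenyl on a nitrogen on an aromatic ring gives a 1.3-fold higher number from compound 2 to compound 3 (0.10 log units; within the scatter) and so shows that the two groups are not told apart here, although both the halogen and its place on the phenyl ring change in this one exchange. No measurement bears on why these two groups fall so close.

As far as these compounds go, whether an amine or a carboxylic acid on the phenyl ring, or a longer chain on this nitrogen in place of the ring, would move the number beyond the scatter stays open. Compound 1 differs from compound 2 and compound 3 in more than one place, so what the acrylamide group contributes also cannot be read.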